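A Hydroxy Group Added to a Weak Inhibitor

A few compounds are considered here, and "the series" means these few. Any claim that something is new, unique, unknown or untested is made for them only; others in the source may bear on it.

Measured so far:
compound 1 `Brc1ccc2nc(-c3ccccc3)cc(-c3ccccc3)c2c1`: 128000 nM
compound 2 `O=[N+]([O-])c1cccc(-c2cc(-c3ccccc3)c3cc(Br)ccc3n2)c1`: "not determined" (no result reported)

Going by the values given here, in a functional assay on Hep2C cells (Homo sapiens) for antiproliferative activity, read by MTT assay, with a stated time of 24 h (a higher number here means a weaker inhibitor, a lower number a stronger inhibitor), compound 1 gives 128000 nM, the only number in this set, so it is the sole point of comparison; for compound 2 this assay gives "not determined" (no result reported). Compound 3 `Oc1ccc(-c2cc(-c3ccccc3)c3cc(Br)ccc3n2)cc1` differs from compound 1 by hydroxy in place of hydrogen on an aromatic carbon. Among the compounds with values here, no pair of measured compounds shows how such a change moves the number, so the expectation rests on compound 1 alone. The step of a 1.6-fold lower number from compound 1 to compound 3 (0.20 log units; within the scatter) is expected to be small, toward a somewhat stronger inhibitor, but not clearly beyond the usual scatter. Compound 3 is therefore estimated at 80000 nM, within 25000 nM to 250000 nM.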

Compound 3, half-maximal inhibitory concentration: 105000 nM
The estimate for compound 3 lay 1.3-fold (0.12 log units) below the measured number, within the range that was stated.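

In this assay, the first measured pair gives a 1.2-fold lower number from compound 1 to compound 3 (0.09 log units; within the scatter), so hydroxy in place of hydrogen at this place, para to a large group, leaves the two compounds indistinguishable. Both numbers also remain in the same weak range that compound 1 set on its own. No outside measurement bears on this result. As far as these compounds go, whether an amine or a carboxylic acid at the same place would move the number beyond the scatter remains open. So does the effect of a hydroxy group elsewhere on the shared core.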